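Acid ceramidase series: small halogen replacing biaryl

The source may hold more compounds than are shown below. What is called first, only, known or untested is meant among the compounds shown, and "the series" means these compounds.

Measured so far:
compound 1 `O=C(NCCCCc1ccccc1)n1c(=O)oc2ccc(Br)cc21`, 22 nM
compound 2 `O=C(NCCCCc1ccccc1)n1c(=O)oc2ccc(-c3ccc(F)cc3)cc21`, 56 nM
compound 3 `COc1ccc(-c2ccc3oc(=O)n(C(=O)NCCCCc4ccccc4)c3c2)cc1`, 67 nM

In an assay on HEK293 cells for inhibition of acid ceramidase (Homo sapiens), with a stated time of 10 min (a higher number here means a weaker inhibitor, a lower number a stronger inhibitor), compound 3 gives the highest of the three numbers. Compound 2 lies nearest, and a 1.2-fold higher number from compound 2 to compound 3 (0.08 log units; within the scatter) is within the scatter, so the two biaryl compounds are not distinguished. Compound 1 lies furthest, the step being a 3.0-fold higher number from compound 1 to compound 3 (0.48 log units; beyond the scatter).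

Compound 4 `O=C(NCCCCc1ccccc1)n1c(=O)oc2ccc(F)cc21` is not yet measured. The change from compound 3 is fluoro in place of 4-methoxyphenyl on an aromatic carbon.

For the measured compounds named here, the steps that bear on it are a 2.5-fold higher number from compound 1 to compound 2 (0.41 log units; beyond the scatter) and a 3.0-fold higher number from compound 1 to compound 3 (0.48 log units; beyond the scatter): replacing bromo with either aryl group raised the number modestly, beyond the scatter. The change to compound 4 runs the opposite way, from a biaryl back to a single small halogen, so a step down of about that size is expected. Nothing here compares fluoro with bromo directly, which widens the range. Compound 4 is estimated at 30 nM, within 12 nM to 80 nM. This estimate means a step of a 2.2-fold lower number from compound 3 to compound 4 (0.35 log units; beyond the scatter).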

Compound 4, half-maximal inhibitory concentration: 12 nM
The estimate for compound 4 lay 2.5-fold (0.40 log units) above the measured number; the range from low to high includes it.
By their numbers in this assay, from the lowest: compounds 4 and 1 (each within the scatter of the next); then compounds 2 and 3 (each within the scatter of the next).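

In this assay, fluoro in this place, on an aromatic carbon of the six-membered ring, reverses the cost of the biaryl groups: a 5.6-fold lower number from compound 3 to compound 4 (0.75 log units; beyond the scatter) and a 4.7-fold lower number from compound 2 to compound 4 (0.67 log units; beyond the scatter) are both beyond the scatter. Against bromo, a 1.8-fold lower number from compound 1 to compound 4 (0.26 log units; within the scatter) stays within the scatter, so the two halogens are not distinguished at this position. Among the four compounds, both halogens now read lower than both aryl groups, with no compound against that pattern, and no data here explain the gap.

Open, going by these compounds, is how a plain phenyl, a methyl or a methoxy group directly on this carbon would read, and whether a carboxylic acid or an amine on the outer aryl ring would shift the biaryl numbers. On these data alone, all four compounds also carry the same 4-phenylbutyl chain, so whether this order holds with a shorter or longer chain remains untested.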